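The compounds below may be only part of what the source reports. "The series", "measured", "known", "first", "only" and "open" are said of these compounds alone.

Measured so far in a functional assay on cells for antagonist activity at prostaglandin E2 receptor EP1 subtype (Rattus norvegicus), read by fluorescence and calcium flux, with a stated time of 60 s; on this read-out lower numbers stand for stronger inhibition and higher numbers for weaker inhibition:
compound 1 `O=C(O)c1cccc(Cc2c(-c3ccccc3)nn3cc(F)ccc23)n1`: 380 nM
compound 2 `CS(=O)(=O)c1ccc2c(Cc3cccc(C(=O)O)n3)c(-c3ccccc3)nn2c1`: 5400 nM
compound 3 `O=C(O)c1cccc(Cc2c(-c3ccco3)nn3cc(Cl)ccc23)n1`: 1200 nM

Of these three numbers, compound 3 holds the second highest in this assay: compound 1, with the lower number, is its nearest neighbour, and compound 2, with the higher number, lies furthest away, both gaps being beyond the usual scatter. Compound 4 `O=C(O)c1cccc(Cc2c(N3CCCCC3)nn3cc(Cl)ccc23)n1` has not yet been measured. It differs from compound 3 in one place: piperidin-1-yl in place of furan-2-yl on an aromatic carbon. Among the compounds with values here, the only measured step between compounds that differ in one place is a 14-fold higher number from compound 1 to compound 2 (1.15 log units; beyond the scatter), a change elsewhere on the shared core, so it says little about exchanging the whole ring altered here. Within the data shown here, compound 1 and compound 3 differ in two places at once, and their two values show only that compound 3 gives the higher number. Among the measured compounds shown here, with no direct precedent, the expectation is uncertain. The estimate for compound 4 in this assay is 2500 nM, expected to fall between 600 nM and 10000 nM. This estimate implies an expected step of a 2.1-fold higher number from compound 3 to compound 4 (0.32 log units; beyond the scatter), towards weaker inhibition.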

Compound 4, half-maximal inhibitory concentration: 79 nM
For compound 4 the middle estimate is 32-fold (1.50 log units) above the measured one; measured number below the stated range.
By their numbers in this assay, from the lowest: compound 4; then compound 1; then compound 3; then compound 2.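

In this assay, putting piperidin-1-yl in place of furan-2-yl gives a 15-fold lower number from compound 3 to compound 4 (1.18 log units; beyond the scatter), a large move towards stronger inhibition. This aromatic carbon therefore does not need a five-membered aromatic ring: a six-membered non-aromatic ring is not only accepted here but gives the lower number. Nothing measured here explains why this exchange has so large an effect.

The compounds shown leave open whether the effect belongs to piperidin-1-yl specifically or to non-aromatic amine rings more widely, which a group such as pyrrolidin-1-yl, morpholin-4-yl or an open-chain diethylamino group at this carbon would help to settle. As far as these compounds go, it also remains open whether the same exchange would have a similar effect with fluoro or methylsulfonyl in place of the chloro group on the shared core.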